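The source may hold more compounds than are shown below. What is called first, only, known or untested is meant among the compounds shown, and "the series" means these compounds.

Three close relatives share a core built around a bromo-fluoro-substituted aniline: compound 1 `C[C@H](CSc1nonc1/C(=N/O)Nc1ccc(F)c(Br)c1)NC(=O)CS(N)(=O)=O`, compound 2 `CS(=N)(=O)CC(=O)NCCSc1nonc1/C(=N/O)Nc1ccc(F)c(Br)c1` and compound 3 `NS(=O)(=O)CC(=O)NCCSc1nonc1/C(=N/O)Nc1cccc(Br)c1`. Each was examined in an ADME assay on isolated protein for pharmacokinetics, with UDP-glucuronosyltransferase 1A9 (Homo sapiens) as the target, read by LC-MS, with a stated time of 60 min, at 37 degrees C, tested at 1 uM, in the presence of a further agent that is not named here; on this read-out lower numbers stand for a shorter-lived compound and higher numbers for a longer-lived compound. In this assay compound 1 gives 1.33 h, compound 2 gives 1.53 h and compound 3 gives 0.955 h. Compound 2 sits alongside the other two: its gap to compound 1 and its gap to compound 3 both lie within the scatter of repeated measurements, so the three numbers cannot be told apart with confidence.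

Compound 4 `CS(=O)(=O)NCCSc1nonc1/C(=N/O)Nc1ccc(F)c(Br)c1` has not yet been measured. It differs from compound 2 in one place: a group of 4 heavy atoms (1 carbon, 2 oxygen, 1 sulfur; no ring) in place of a group of 7 heavy atoms (3 carbon, 1 nitrogen, 2 oxygen, 1 sulfur; no ring), on an amine nitrogen. Among the compounds with values here, no measured pair in this set shows what such a swap does on this read-out, so no step size can be taken from the data. Because compound 1 gives 1.33 h, compound 2 gives 1.53 h and compound 3 gives 0.955 h, three numbers that cluster tightly, the expectation is that compound 4 stays in that cluster, with a step of a 1.2-fold lower number from compound 2 to compound 4 (0.07 log units; within the scatter) not beyond the scatter. Compound 4 is therefore estimated at 1.3 h, with a likely range from 0.6 h to 2.8 h.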

Compound 4, half-life: 0.357 h
Estimate against measurement, compound 4: 3.6-fold (0.56 log units) above; the whole stated range lies above it.
By their numbers in this assay, from the lowest: compound 4; then compounds 3, 1 and 2 (each within the scatter of the next).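

In this assay the swap of the group of 7 heavy atoms for methylsulfonyl, on an amine nitrogen, brings a 4.3-fold lower number from compound 2 to compound 4 (0.63 log units; beyond the scatter) in this single pair. The three earlier compounds could not be told apart and gave no sign that this position could move the half-life, whereas this pair shows that a change here can shorten it beyond ordinary measurement noise. No measurement shown here explains the drop.

One pair cannot show whether the shorter half-life follows from the methylsulfonyl group itself or from losing the rest of the larger group. The compounds shown also leave open how an acetyl group on that amine nitrogen, or an ethylsulfonyl group in place of methylsulfonyl, would read.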